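The source may hold more compounds than are shown below. What is called first, only, known or untested is meant among the compounds shown, and "the series" means these compounds.

Measured compounds:
Compound 1 `O=c1c2ncn(-c3ccccc3)c2nc(N2CCCCC2)n1-c1ccc(Cl)cc1` – > 100000 nM in a functional assay on OVCAR-3 cells (Homo sapiens) for cytotoxicity, read by MTT assay, with a stated time of 72 h; on this read-out lower numbers stand for stronger inhibition and higher numbers for weaker inhibition
Compound 2 `CCNc1nc2c(ncn2-c2ccccc2)c(=O)n1-c1ccccc1` – > 100000 nM in this assay

Neither of these values is a number. For compound 1 the reading > 100000 nM is a limit of the assay, meaning no measurable inhibition was seen up to that concentration. For compound 2 the reading > 100000 nM is likewise a limit. On the numbers shown, compound 1 therefore stands at the top of the scale together with the only other compound measured, as the limit of > 100000 nM in this assay, at which 2 of the 2 values shown sit, makes plain.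

Compound 3 `CNc1nc2c(ncn2-c2ccccc2)c(=O)n1-c1ccc(Cl)cc1` has not yet been measured. It differs from compound 1 in one place: methylamino in place of piperidin-1-yl on an aromatic carbon. Within the data shown here, no step between two measured compounds exists to gauge how such a swap shifts the read-out in this assay. With both measured compounds sitting at the limit, no change beyond the scatter is expected, so the step of a number no higher from compound 1 to compound 3 (the limit leaves the size open) is estimated as essentially flat. Compound 3 is accordingly expected to read about 100000 nM, within 30000 nM to 300000 nM, most likely again only as a limit.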

Compound 3, half-maximal inhibitory concentration: > 100000 nM
Compound 3: no number, only a limit; the forecaster's own chance of this, stated with the estimate: 85%; the middle value lies on the limit itself.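

Compound 1 and compound 3 both read only as limits, not as numbers, so the swap of piperidin-1-yl for methylamino between them cannot be sized: the limit of > 100000 nM in this assay, at which 3 of the 3 values shown sit. What change to the shared core, if any, would give a measurable value in this assay remains open across the compounds shown.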